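Swapping a side chain on a chloro-bearing core

The source may report more compounds than this note shows. Statements on the series, on what has been measured and on what is new or still open speak of the compounds shown alone.

Three compounds of one series were tested in a functional assay on the whole organism (Tail, strain ICR) with Mus musculus as the target, in the tail flick test, with a stated time of 150 min, at a dose of 25 umol/kg by the oral route; a lower number here means a weaker effect, a higher number a stronger effect of the compound at the dose given. Compound 1, `N=C(N)NCCC[C@H](NC(=O)CN(c1ncnc2c1ncn2C1CCCCO1)C1CC1)C(=O)OCc1ccccc1`, gives 19.6% in this assay. Compound 2, `O=C(CN(c1ncnc2c1ncn2C1CCCCO1)C1CC1)N[C@@H](CO)C(=O)OCc1ccccc1`, gives 18.3% in this assay. Compound 3, `CSCC[C@H](NC(=O)CN(c1nc(Cl)nc2[nH]cnc12)C1CC1)C(=O)OCc1ccccc1`, gives 17.6% in this assay, so its number lies within the scatter of both compound 1 and compound 2, and the three values sit close together.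

Compound 4, `N=C(N)NCCC[C@H](NC(=O)CN(c1nc(Cl)nc2[nH]cnc12)C1CC1)C(=O)OCc1ccccc1`, is not yet measured. It differs from compound 3 by a group of 5 heavy atoms (2 carbon, 3 nitrogen; no ring) in place of a group of 2 heavy atoms (1 carbon, 1 sulfur; no ring), on a saturated chain carbon, three bonds along the chain from an amide-type nitrogen and a carbonyl carbon. Within the data shown here, the one step that bears on this exchange is the side-chain swap a number 1.3 percentage points lower from compound 1 to compound 2 (within the scatter), where the group that enters compound 4 left compound 1 without a shift beyond the scatter. Compound 1 already carries that group on a different core and gives a number close to compound 3. No step beyond the scatter is therefore expected here; the step of a number 1.4 percentage points higher from compound 3 to compound 4 (within the scatter) is the estimate. Compound 4 is expected to give 19% in this assay, between 9% and 30%.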

Compound 4, a percentage reported as activity, at one dose (the size of the read-out at that dose, not a potency): 6.12%
Compound 4: middle estimate off by 12.9 percentage points, on the high side, and the stated range ends above it.
By their numbers in this assay, from the lowest: compound 4; then compounds 3, 2 and 1 (each within the scatter of the next).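

With the core of compound 3 held fixed, the side chain on a saturated chain carbon, three bonds along the chain from an amide-type nitrogen and a carbonyl carbon, proves able to move the read-out: replacing methylsulfanyl with the group of 5 heavy atoms gives a number 11.5 percentage points lower from compound 3 to compound 4 (beyond the scatter) in this assay at this dose. The only earlier step, a number 1.3 percentage points lower from compound 1 to compound 2 (within the scatter) on another core and with a different exchange, had shown no change beyond the scatter, so it could not reveal this sensitivity. No measurement shown gives a reason for the step.

Going by these compounds, whether an amine or a carboxylic acid at the end of this side chain would stay near compound 3 or compound 4 remains open. Also open, on these data alone, is whether methylsulfanyl on the core of compound 1 would give a step of similar size.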